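Swapping Fluoro for Methoxy in a Cinnamate Ester Series

The source may hold more compounds than are shown below. What is called first, only, known or untested is meant among the compounds shown, and "the series" means these compounds.

Three esters built on the shared core were tested in a functional assay on the whole organism (strain Kunming) with Mus musculus as the target, with a stated time of 0.5 h, at a dose of 100 mg/kg by the intraperitoneal route; a higher number here means a weaker effect of the compound at the dose given, a lower number a stronger effect. Compound 1 `COc1cc(OC)c(OC)cc1/C=C/COC(=O)/C=C/c1c(OC)ccc(OC)c1OC` gives 100%, compound 2 `COc1cc(OC)c(OC)cc1/C=C/COC(=O)/C=C/c1ccc(F)cc1` gives 100%, and compound 3 `COc1cc(OC)c(OC)cc1/C=C/COC(=O)/C=C/c1cc(OC)c(OC)c(OC)c1OC` gives 75%. Compound 2 thus stands level with compound 1 at the digits reported, the two together forming the highest pair of the three numbers, with no change between them within the scatter; compound 3 lies lower than compound 2, a gap beyond the scatter.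

The next compound, compound 4 `COc1ccc(/C=C/C(=O)OC/C=C/c2cc(OC)c(OC)cc2OC)cc1`, differs from compound 2 in a single place: methoxy in place of fluoro on an aromatic carbon, so that 4-fluorophenyl becomes 4-methoxyphenyl. Among the compounds with values here, no measured pair in this set shows this particular change, so there is no step to lean on. Since compound 1 and compound 2 sit at the same reading in this assay, the expected step of a number 5 percentage points lower from compound 2 to compound 4 (within the scatter) is none beyond the scatter, or a slight fall at most. Compound 4 is therefore estimated at 95%, within a range from 75% to 100%.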

Compound 4, a percentage reported as activity, at one dose (the size of the read-out at that dose, not a potency): 100%
Estimate against measurement, compound 4: 5 percentage points below; the range from low to high includes it.
By their numbers in this assay, from the lowest: compound 3; then compounds 1, 2 and 4 (each within the scatter of the next).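

In this assay, within the data shown here, methoxy in place of fluoro on an aromatic carbon, para to a large group, gives no change at the digits printed from compound 2 to compound 4 (within the scatter) and is the first change in this set that can be read at a single place. At the one dose tested, the 4-fluorophenyl and 4-methoxyphenyl esters therefore cannot be told apart, and this position accepts either group with the reading held within the scatter. Nothing available offers an explanation for this outcome.

As far as these compounds go, whether an amine, a carboxylic acid or a longer chain such as butoxy at the same position would shift the reading away from that of compound 2 remains open. From the compounds shown here alone, it is also open whether fluoro and methoxy would still read alike at another dose or at another stated time.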